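This account rests on a few compounds, and the source may have more. Where it says the series, first, only, none or still open, it means among the compounds named here.

Working notes on the series.

Two compounds of the shared core carry numbers in a functional assay on MCF7 cells (Homo sapiens) for antiproliferative activity, read by sulforhodamine B assay, with a stated time of 48 h; on this read-out higher numbers stand for weaker inhibition and lower numbers for stronger inhibition. Compound 1, `O=C1NCCN1c1ccc(S(=O)(=O)Nc2ccc3[nH]ccc3c2)cc1`, gives 170 nM in this assay. Compound 2, `Cc1ccc(NS(=O)(=O)c2ccc(N3CCNC3=O)cc2)cc1C`, gives 230 nM in this assay. The two numbers lie within the usual scatter of each other, so compound 2 and compound 1 cannot be told apart on these data; compound 2 is simply the second of the two measured points, and its nearest neighbour is compound 1.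

Compound 3, `Cc1cccc(NS(=O)(=O)c2ccc(N3CCNC3=O)cc2)c1C`, has not been measured in this assay. The change from compound 2 is 2,3-dimethylphenyl in place of 3,4-dimethylphenyl on a sulfonamide nitrogen. Within the data shown here, no step between measured compounds describes a rearrangement of this kind, so there is no measured anchor for the size of its effect. With the same atoms joined differently, and with compound 1 at 170 nM and compound 2 at 230 nM sitting close together, the expected step is small, at most a slight drift toward a higher number, and not clearly beyond the scatter: the step expected from compound 2 to compound 3 is a 1.3-fold higher number from compound 2 to compound 3 (0.12 log units; within the scatter). Compound 3 is therefore estimated at 300 nM in this assay, with a range of 120 nM to 900 nM.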

Compound 3, half-maximal inhibitory concentration: 230 nM
Beside the measured number, compound 3's estimate is 1.3-fold (0.12 log units) above it; the range from low to high includes it.
By their numbers in this assay, from the lowest: compounds 1, 2 and 3 (each within the scatter of the next).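

The first step measured at this place, 2,3-dimethylphenyl in place of 3,4-dimethylphenyl on a sulfonamide nitrogen, gives no change at the digits printed from compound 2 to compound 3 (within the scatter) in this assay. The earlier compounds shown here offered no such one-place comparison, and this pair now shows that this one rearrangement of the two methyl groups, with the atoms unchanged, leaves no difference that can be read in this assay, though one pair sets no rule for the series. No measurement at hand bears on this result, so nothing can be said about what lies behind it.

Still open, as far as these compounds go, is how far this flat response extends to groups of another kind on the sulfonamide nitrogen, such as a phenyl ring carrying a carboxylic acid or an amine, or a longer alkyl chain in place of the dimethylphenyl group. Also open, from the compounds shown here alone, is whether a plain phenyl ring, with neither methyl group, or a phenyl ring with a single methyl group would stay within the scatter of compound 2 and compound 3.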